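Ring amine nitrogen substituents and cytotoxicity notes

The compounds below may be only part of what the source reports. "The series", "measured", "known", "first", "only" and "open" are said of these compounds alone.

Measured so far:
compound 1 `NCCNc1cc(N2CCN(S(=O)(=O)c3ccccc3)CC2)nc2ccccc12`: 20500 nM
compound 2 `NCCNc1cc(N2CCN(C(=O)CCc3ccccc3)CC2)nc2ccccc12`: > 100000 nM, a limit of the assay
compound 3 `NCCNc1cc(N2CCN(C(=O)C3(c4ccccc4)CCC3)CC2)nc2ccccc12`: > 100000 nM, a limit of the assay

In an ADME assay on HEp-2 cells (Homo sapiens) for cytotoxicity, read by CCK-8 assay, with a stated time of 6 days (on this read-out higher numbers stand for lower toxicity in this test and lower numbers for higher toxicity in this test), compound 1 is the only one of the three with a number. Compound 2 is reported only as a limit, and this is where it stands relative to the others: at the limit of > 100000 nM in this assay, at which 2 of the 3 values shown sit, shared with compound 3. Among the measured compounds shown here, the one readable step, an at least 4.8-fold higher number from compound 1 to compound 2 (0.68 log units; beyond the scatter), moved toward lower toxicity when phenylsulfonyl gave way to phenethylcarbonyl. The step that the two limits leave unreadable from compound 2 to compound 3 cannot be sized.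

Compound 4 `CS(=O)(=O)N1CCN(c2cc(NCCN)c3ccccc3n2)CC1` is not yet measured. It differs from compound 2 as methylsulfonyl in place of phenethylcarbonyl on an amine nitrogen in a ring. For the measured compounds named here, only the step from compound 1 to compound 2 bears on it, and in reverse: a sulfonyl returns, though methylsulfonyl is a smaller group than phenylsulfonyl. A move back toward the number of compound 1 is therefore expected, but of modest size and with wide uncertainty; the estimated step is an at least 2.0-fold lower number from compound 2 to compound 4 (0.30 log units; that floor lies within the scatter). Compound 4 is expected at 50000 nM, within 12000 nM to 100000 nM in this assay.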

Compound 4, half-maximal cytotoxic concentration: > 100000 nM
Compound 4 ended at the assay's limit; the forecaster's own chance of this, stated with the estimate: 45%; middle value at least 2.0-fold (0.30 log units) from the limit.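

In this assay compound 4 is reported only as a limit of the assay, not as a number: the limit of > 100000 nM in this assay, at which 3 of the 4 values shown sit. A sulfonyl on the ring amine nitrogen is thus not enough to give the lower number of compound 1, as methyl in place of phenyl on the sulfonyl sulfur gave an at least 4.8-fold higher number from compound 1 to compound 4 (0.68 log units; beyond the scatter). Of the four compounds, only compound 1, with phenylsulfonyl, has a number, so the measurable toxicity here goes with the phenyl on the sulfur and not with the sulfonyl alone, while the steps among compound 2, compound 3 and compound 4 cannot be read.

From the compounds shown here alone, how these three compounds order beyond the limit stays open. Also open, going by these compounds, is whether an ethyl or a cyclopropyl on the sulfonyl sulfur, or a chlorophenyl in place of the phenyl, would bring a number back within range.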